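Swapping the piperidine amide for a thiazolyl amide

The source may hold more compounds than are shown below. What is called first, only, known or untested is meant among the compounds shown, and "the series" means these compounds.

For the measured compounds named here, compound 1 `O=C(c1cccc(Nc2ncc(F)c(Nc3ccc(F)cc3)n2)c1)N1CCCCC1` is the only member of this small set that gives a readable number: in a functional assay on KB cells (Homo sapiens) for antiproliferative activity, read by sulforhodamine B assay, with a stated time of 3 days (on this read-out lower numbers stand for stronger inhibition of growth and higher numbers for weaker inhibition of growth), compound 1 gives 14800 nM. Compound 2 `COc1ccc(NC(=O)c2cccc(Nc3ncc(F)c(Nc4ccc(F)cc4)n3)c2)cc1` reaches only the limit of the assay, giving > 10000 nM in this assay. Compound 3 `O=C(Nc1cccc(Nc2ncc(F)c(Nc3ccc(F)cc3)n2)c1)c1ccccc1` likewise gives only a limit, > 10000 nM in this assay. Because of the limit of > 10000 nM in this assay, at which 2 of the 3 values shown sit, the steps among the measured compounds cannot be sized: a step that the limit leaves unreadable from compound 1 to compound 2, a step that the limit leaves unreadable from compound 1 to compound 3 and a step that the two limits leave unreadable from compound 2 to compound 3 all stay unreadable.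

Compound 4 `O=C(Nc1nccs1)c1cccc(Nc2ncc(F)c(Nc3ccc(F)cc3)n2)c1` differs from compound 1 in one place ((1,3-thiazol-2-yl)amino in place of piperidin-1-yl on a carbonyl carbon). It shares with compound 2 the pattern of an amide whose nitrogen carries an aromatic ring, and compound 2 in this assay sits at the limit, so the comparison suggests compound 4 will land at or beyond the limit too. A tightening of growth inhibition is not indicated by anything shown, so the expected step of a 1.4-fold higher number from compound 1 to compound 4 (0.13 log units; within the scatter) is toward weaker inhibition or no change beyond the scatter. The estimate for compound 4 in this assay is 20000 nM, expected to fall within 8000 nM to 60000 nM.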

Compound 4, concentration for 50% growth inhibition: > 10000 nM
Compound 4 gave a limit, no number (the forecaster's own chance of this, stated with the estimate: 60%); the middle value lies beyond the limit too.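

No new step can be read from compound 4, which gives only a limit, so its steps to compound 1, compound 2 and compound 3 all stay unsized for this reason: the limit of > 10000 nM in this assay, at which 3 of the 4 values shown sit.

The compounds shown leave open whether compound 2, compound 3 and compound 4 truly differ from one another or from compound 1 in growth inhibition.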